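Swapping the Ring at the End of the Shared Core

The source may hold more compounds than are shown below. What is called first, only, known or untested is meant among the compounds shown, and "the series" means these compounds.

Measured in a functional assay on HEK293 cells for agonist activity at Bombesin receptor subtype-3 (Homo sapiens), read by luminescence and calcium flux, with a stated time of 10 min; a higher number here means that more compound is needed for the effect, a lower number that less compound is needed:
Compound 1, `CCC(C)(C)Cc1c[nH]c(CCc2ccc(-c3cnccn3)cc2)n1`: 100 nM
Compound 2, `CCC(C)(C)Cc1c[nH]c(CCc2ccc(-c3ccccc3C(=O)O)cc2)n1`: 101 nM
Compound 3, `CCC(C)(C)Cc1c[nH]c(CCc2ccc(-c3csnn3)cc2)n1`: 104 nM

On the bare numbers compound 3 sits at the top of the three, yet the steps of a 1.0-fold higher number from compound 1 to compound 3 (0.02 log units; within the scatter) and a 1.0-fold higher number from compound 2 to compound 3 (0.01 log units; within the scatter) both lie within the scatter, so the three compounds are effectively indistinguishable. The same holds for a 1.0-fold higher number from compound 1 to compound 2 (0.00 log units; within the scatter).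

Compound 4, `CCC(C)(C)Cc1c[nH]c(CCc2ccc(-c3cnsc3)cc2)n1`, carries one change relative to compound 3: 1,2-thiazol-4-yl in place of 1,2,3-thiadiazol-4-yl on an aromatic carbon. All three measured steps bear on this move, since each of them swaps the group at this same position, and none of them shifted the number beyond the scatter. The expected step is therefore a 1.0-fold lower number from compound 3 to compound 4 (0.02 log units; within the scatter), with no change beyond the scatter. Compound 4 is estimated at 100 nM, with a range from 40 nM to 250 nM.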

Compound 4, half-maximal effective concentration: 100 nM
Compound 4: middle estimate and measured number agree at the digits printed; the measured number falls inside the stated range.
By their numbers in this assay, from the lowest: compounds 1, 4, 2 and 3 (each within the scatter of the next).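

Going from a five-membered aromatic ring with 3 hetero atoms to one with 2 hetero atoms gives a 1.0-fold lower number from compound 3 to compound 4 (0.02 log units; within the scatter), so even this small change within one ring family leaves the number in place. The comparisons with the larger six-membered rings read the same way, with a 1.0-fold lower number from compound 2 to compound 4 (0.00 log units; within the scatter) and no change at the digits printed from compound 1 to compound 4 (within the scatter). Nothing available explains why these swaps make so little difference.

Every group shown at this position is a ring, so whether an amine or a longer chain there would move the number beyond the scatter stays open.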